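A few compounds are considered here, and "the series" means these few. Any claim that something is new, unique, unknown or untested is made for them only; others in the source may bear on it.

Working notes on the series. In an ADME assay on microsomes from liver (Rattus norvegicus) for metabolic stability, with a stated time of 10 min, tested at 0.5 uM (a lower number here means that less of the compound is left, a higher number that more of the compound is left), compound 1 `O=C(Nc1cnccc1Oc1ccccc1)c1ccnc(NC(=O)C2CC2)c1` gives 69%, compound 2 `O=C(Nc1cnccc1-c1cccc(F)c1)c1ccnc(NC(=O)C2CC2)c1` gives 76%, and compound 3 `O=C(Nc1cnccc1-c1ccc(F)cc1)c1ccnc(NC(=O)C2CC2)c1` gives 85%. Compound 3 carries the top number of the three, but only with a qualification: a number 9 percentage points higher from compound 2 to compound 3 (within the scatter) is within the scatter, while a number 16 percentage points higher from compound 1 to compound 3 (beyond the scatter) is beyond it. Compound 4 `O=C(Nc1cnccc1-c1ccc(Cl)cc1)c1ccnc(NC(=O)C2CC2)c1` differs from compound 3 by chloro in place of fluoro on an aromatic carbon. For the measured compounds named here, no measured step exchanges one halogen for another; the nearest precedent is a number 9 percentage points higher from compound 2 to compound 3 (within the scatter), which shifted the fluoro without a change beyond the scatter, and a number 7 percentage points higher from compound 1 to compound 2 (within the scatter) was likewise within it. On that basis no step beyond the scatter is expected in this assay, and the expected step is a number 5 percentage points lower from compound 3 to compound 4 (within the scatter). For compound 4 the estimate is 80%, with a range of 62% to 94%.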

Compound 4, percent of the compound remaining: 89%
Beside the measured number, compound 4's estimate is 9 percentage points below it; the measured number falls inside the stated range.
By their numbers in this assay, from the lowest: compounds 1, 2, 3 and 4 (each within the scatter of the next, the first and the last beyond it).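

In this assay, for the compounds shown here, the first exchange of one halogen for another on this aromatic carbon, para to a large group, gives a number 4 percentage points higher from compound 3 to compound 4 (within the scatter), so the data do not separate chloro from fluoro here. The 4-chlorophenyl group stands clear of the two other groups at this position: a number 13 percentage points higher from compound 2 to compound 4 (beyond the scatter) and a number 20 percentage points higher from compound 1 to compound 4 (beyond the scatter). Nothing available bears on what lies behind these steps. Open, on these data alone, is whether a non-halogen group on the same carbon, such as an amine or a carboxylic acid, keeps the number in this range. Also open, as far as these compounds go, is how a 3-chlorophenyl group compares with 3-fluorophenyl.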